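The source may report more compounds than this note shows. Statements on the series, on what has been measured and on what is new or still open speak of the compounds shown alone.

Working notes on the series. The shared core is that of compound 1 `CCCCCCNC(=O)CS(=O)(=O)Nc1c(C(C)C)cccc1C(C)C`, an amide carrying a hexyl chain on its nitrogen. In an assay on microsomes from intestine for inhibition of acyl-CoA:cholesterol acyltransferase (Oryctolagus cuniculus) (on this read-out lower numbers stand for stronger inhibition and higher numbers for weaker inhibition), compound 1 gives only a limit, > 5000 nM, and no number. Compound 2 `CCCCCCCCCCCCNC(=O)CS(=O)(=O)Nc1c(C(C)C)cccc1C(C)C` carries a longer chain on the same nitrogen; in this assay compound 2 gives 320 nM. Compound 3 `CCCCCCCCCCCCC(C)OC(=O)CS(=O)(=O)Nc1c(C(C)C)cccc1C(C)C` is the corresponding ester with a branched long chain, and in this assay compound 3 gives 21 nM. Within the data shown here, the one step measured in a single place is an at least 15-fold lower number from compound 1 to compound 2 (1.19 log units; beyond the scatter); it starts from the limit (the limit of > 5000 nM in this assay, at which 1 of the 3 values shown sits), so only its lower bound is fixed.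

Compound 4 `CCCCCCSC(=O)CS(=O)(=O)Nc1c(C(C)C)cccc1C(C)C` differs from compound 1 by hexylsulfanyl in place of hexylamino on a carbonyl carbon. Among the measured compounds shown here, no measured step covers this exchange at the carbonyl carbon: the step from compound 1 to compound 2 concerns the length of the chain and leaves the carbonyl substituent untouched, and compound 3 changes both the chain and the carbonyl substituent at once. Compound 4 keeps the hexyl chain of compound 1, whose reading is a limit, so the starting point itself is not fixed. Compound 4 is therefore expected to remain weak, with the step of an at least 1.2-fold lower number from compound 1 to compound 4 (0.09 log units; that floor lies within the scatter) estimated as small against that limit. Compound 4 is expected to give about 4000 nM in this assay, within 800 nM to 20000 nM, and a further limit reading would not surprise.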

Compound 4, half-maximal inhibitory concentration: 1000 nM
Beside the measured number, compound 4's estimate is 4.0-fold (0.60 log units) above it; the range from low to high includes it.
By their numbers in this assay, from the lowest: compound 3; then compound 2; then compound 4. At a limit, above all of these: compound 1.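

The exchange of hexylamino for hexylsulfanyl on a carbonyl carbon gives an at least 5.0-fold lower number from compound 1 to compound 4 (0.69 log units; beyond the scatter). Among these compounds, this is the only step that alters the carbonyl substituent while the hexyl chain stays the same, so in this assay the reading responds to this position alone, whereas the earlier step from a shorter to a longer chain left the carbonyl substituent untouched and compound 3 changed both places at once. The true size of the new step stays unfixed, as its starting point, compound 1, is a limit and only a floor can be read: the limit of > 5000 nM in this assay, at which 1 of the 4 values shown sits.

Hexyloxy on the same carbonyl carbon, with the hexyl chain kept, would show whether the step goes with the sulfur itself or with the loss of the amide hydrogen, which the exchange removes in the same move. Dodecylsulfanyl in that place would show whether the chain-length step measured on the amide, an at least 15-fold lower number from compound 1 to compound 2 (1.19 log units; beyond the scatter), also holds with sulfur in place of the amide nitrogen.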